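Chain extension in the alkynyl series: compound 4

The compounds below may be only part of what the source reports. "The series", "measured", "known", "first", "only" and "open" are said of these compounds alone.

Compound 1 `CCCCCCC#Cc1cc2cn(COCCO)c(=O)nc2o1` and compound 2 `CCCCCCCC#Cc1cc2cn(COCCO)c(=O)nc2o1` share a core and differ by a single chain carbon; compound 3 `CCCCCCCc1cc2cn(COCCO)c(O)nc-2n1` carries a saturated chain on a different core. In a functional assay on HEL cells (Homo sapiens), read by microscopy (on this read-out higher numbers stand for lower toxicity in this test and lower numbers for higher toxicity in this test), compound 2 gives 200000 nM. Compound 1 in this assay gives only a limit, > 200000 nM. Compound 3 in this assay likewise gives only a limit, >= 400000 nM. Going by the values given here, compound 2 therefore stands as the only numeric value in this assay; the other two entries are limits.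

Among the compounds with values here, the one measured step bearing on the series is a number no higher from compound 1 to compound 2 (the limit leaves the size open); its size cannot be read because compound 1 sits at the limit of > 200000 nM in this assay, at which 1 of the 3 values shown sits.

Compound 4 `CCCCCCCCC#Cc1cc2cn(COCCO)c(=O)nc2o1` differs from compound 2 as follows: methyl in place of hydrogen on a saturated chain carbon, seven bonds along the chain from a triple-bonded carbon. Within the data shown here, with the sole relevant step unreadable in size, no change beyond the scatter is expected in this assay. The step expected from compound 2 to compound 4 is no change at the digits printed from compound 2 to compound 4 (within the scatter). Compound 4 is estimated at 200000 nM, within 100000 nM to 400000 nM, and a further limit rather than a number is expected to be the likelier outcome.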

Compound 4, minimum cytotoxic concentration: >= 20000 nM
Compound 4 gave a limit, no number; the forecaster's own chance of this, stated with the estimate: 60%; the middle value lies beyond the limit too.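

Compound 4 gives >= 20000 nM in this assay as a limit and not a number. The steps to it from compound 1 and from compound 2 therefore cannot be read. The compounds shown leave open whether the added methyl in compound 4 changes toxicity in this test relative to compound 2.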